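Removing the bromo from compound 3: what to expect

A few compounds are considered here, and "the series" means these few. Any claim that something is new, unique, unknown or untested is made for them only; others in the source may bear on it.

Three members of this series have been measured in a functional assay on DU-145 cells (Homo sapiens) for cytotoxicity; on this read-out higher numbers stand for weaker inhibition and lower numbers for stronger inhibition. Compound 1 `COc1ccc(Cn2cc(/C=N\NC(=O)c3c[nH]c4ccccc34)c3ccccc32)cc1` gives 43900 nM, and compound 2 `COc1ccc2c(c1)c(/C=N\NC(=O)c1c[nH]c3ccccc13)cn2Cc1ccc(Cl)cc1` gives 50000 nM. Compound 3 `O=C(N/N=C\c1cn(Cc2ccc(Cl)cc2)c2ccc(Br)cc12)c1c[nH]c2ccccc12` gives 3600 nM, the lowest of the three numbers; its nearest neighbour is compound 1, and the furthest is compound 2, both beyond the scatter. Within this small set, a single measured step bears directly on the ring position in question: a 14-fold lower number from compound 2 to compound 3 (1.14 log units; beyond the scatter).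

Compound 4 `O=C(N/N=C\c1cn(Cc2ccc(Cl)cc2)c2ccccc12)c1c[nH]c2ccccc12` is compound 3 with one change, (hydrogen in place of bromo on an aromatic carbon). No measured pair shows hydrogen in place of bromo at that position, so the direction of the step rests on what is shown for compound 3 and its two neighbours. Compound 1 carries hydrogen at the same position, though with a different group on the benzyl side, and its value together with that of compound 3 suggests that the bromo accompanies the low number. Compound 4 is therefore expected to move back toward the higher numbers, with an estimated step of a 6.9-fold higher number from compound 3 to compound 4 (0.84 log units; beyond the scatter). The estimate for compound 4 in this assay is 25000 nM, expected within 6000 nM to 60000 nM.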

Compound 4, half-maximal inhibitory concentration: 52100 nM
Beside the measured number, compound 4's estimate is 2.1-fold (0.32 log units) below it; the range from low to high includes it.
By their numbers in this assay, from the lowest: compound 3; then compounds 1, 2 and 4 (each within the scatter of the next).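

In this assay the bromo now has a direct hydrogen counterpart on the same core, and removing it gives a 14-fold higher number from compound 3 to compound 4 (1.16 log units; beyond the scatter), a step as large as the one seen on going from methoxy to bromo. Hydrogen and methoxy on this aromatic carbon cannot be told apart, as the change shows a 1.0-fold higher number from compound 2 to compound 4 (0.02 log units; within the scatter), so the low number of compound 3 goes with the presence of the bromo, and the methoxy of compound 2 did not raise the number relative to hydrogen. With hydrogen on this carbon, the swap on the benzyl ring also stays within the scatter, giving a 1.2-fold higher number from compound 1 to compound 4 (0.07 log units; within the scatter), so among these compounds only the bromo separates from the rest.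

On these data alone, it remains open whether a fluoro, a nitrile or an amine on this carbon would follow the bromo or stay with hydrogen and methoxy, and whether the bromo would give the same step with methoxy in place of chloro on the benzyl ring. Nothing available here accounts for why the bromo stands apart from hydrogen and methoxy.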